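A few compounds are considered here, and "the series" means these few. Any claim that something is new, unique, unknown or untested is made for them only; others in the source may bear on it.

Of the compounds shown here, two built on a shared core have been measured in a functional assay on K562 cells (Homo sapiens) for antiproliferative activity, read by MTT assay, with a stated time of 72 h; a lower number here means a stronger inhibitor, a higher number a weaker inhibitor. Compound 1 `COc1ccccc1-c1c(C(=O)c2cc(OC)c(OC)c(OC)c2)sc2ccccc12` carries a 2-methoxyphenyl group and gives 3400 nM, while compound 2 `CCOc1ccc(-c2c(C(=O)c3cc(OC)c(OC)c(OC)c3)sc3ccccc23)cc1` carries a 4-ethoxyphenyl group and gives 3100 nM. Among the measured compounds shown here, the step between them is a 1.1-fold lower number from compound 1 to compound 2 (0.04 log units; within the scatter), which lies within the scatter, so compound 2 stands level with the only other measured compound and the two cannot be told apart.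

Compound 3 `COc1cc(C(=O)c2sc3ccccc3c2Nc2ccccc2)cc(OC)c1OC` differs from compound 2 in one place: anilino in place of 4-ethoxyphenyl on an aromatic carbon. Anilino takes the place of 4-ethoxyphenyl on an aromatic carbon of the five-membered aromatic ring with 1 sulfur, next to the ring atom that bears a large group.

For the measured compounds named here, the one measured step at this place, a 1.1-fold lower number from compound 1 to compound 2 (0.04 log units; within the scatter), was small, but it did not bring in anilino, so the data offer no direct guide to this change. On that thin evidence, no shift beyond the scatter is expected, though the uncertainty is wide in both directions. The expected change is a 1.2-fold lower number from compound 2 to compound 3 (0.09 log units; within the scatter). For compound 3 the estimated value is 2500 nM, with an expected range from 500 nM to 10000 nM.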

Compound 3, half-maximal inhibitory concentration: 2300 nM
Compound 3: the middle estimate sits 1.1-fold (0.04 log units) above what was measured, and the stated range covers the measured number.
By their numbers in this assay, from the lowest: compounds 3, 2 and 1 (each within the scatter of the next).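

In this assay, anilino on this aromatic carbon gives a 1.3-fold lower number from compound 2 to compound 3 (0.13 log units; within the scatter), and the same group set against the 2-methoxyphenyl of compound 1 gives a 1.5-fold lower number from compound 1 to compound 3 (0.17 log units; within the scatter), so compound 3 cannot be told apart from either earlier compound. Among the compounds shown here, this is the first sign that the ring at this place can be attached through a nitrogen, rather than directly through a ring carbon, and that a group with a hydrogen-bond donor can stand here without the number moving beyond the scatter, although one compound is a narrow basis for that reading. Nothing available here offers an explanation for this result.

The three groups shown all carry a six-membered aromatic ring of carbon only, so it remains open whether such a ring is needed at this place, or whether a plain amine, a short chain such as ethyl or a carboxylic acid would give a clearly different number. On these data alone, it also remains open whether a methyl group on the anilino nitrogen, which would remove the hydrogen-bond donor, would leave the number within the scatter.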